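The compounds below may be only part of what the source reports. "The series", "measured", "known", "first", "only" and "open" are said of these compounds alone.

Compound 1 `O=C(Nc1ccccc1)c1cn(Cc2c(F)cccc2F)c2ccc(=O)[nH]c2c1=O` and compound 2 `O=C(Nc1ccc(C(=O)N2CCOCC2)cc1)c1cn(Cc2c(F)cccc2F)c2ccc(=O)[nH]c2c1=O` share one core and differ in a single group on one aromatic carbon. In an in vitro assay on Sf21 cells for inhibition of high affinity 3',5'-cyclic-AMP phosphodiesterase 7A (Homo sapiens), read by scintillation proximity assay, with a stated time of 30 min (on this read-out lower numbers stand for stronger inhibition and higher numbers for weaker inhibition), compound 1 gives 94 nM, and compound 2 gives 188 nM. The step of a 2.0-fold higher number from compound 1 to compound 2 (0.30 log units; within the scatter) shows that adding the (morpholin-4-yl)carbonyl group leaves the number where it was. Of the two numbers measured, compound 2 holds the higher one, but the gap to compound 1 lies within the scatter, so the two cannot be ranked.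

Compound 3 `NS(=O)(=O)c1ccc(NC(=O)c2cn(Cc3c(F)cccc3F)c3ccc(=O)[nH]c3c2=O)cc1` takes the next step: sulfamoyl in place of (morpholin-4-yl)carbonyl on an aromatic carbon. For the measured compounds named here, the only measured step that bears on this carbon is the one from compound 1 to compound 2, and it was small, so changing the group on that same carbon is expected to give a step of similar size. Going by the values given here, no measured pair tells how sulfamoyl compares with (morpholin-4-yl)carbonyl, so a direction cannot be read from the data. The expected step is a 1.3-fold lower number from compound 2 to compound 3 (0.10 log units; within the scatter). In this assay compound 3 is estimated at 150 nM, with a range from 50 nM to 500 nM.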

Compound 3, half-maximal inhibitory concentration: 34 nM
Compound 3: middle estimate off by 4.4-fold (0.64 log units), on the high side; measured number below the stated range.
By their numbers in this assay, from the lowest: compound 3; then compounds 1 and 2 (each within the scatter of the next).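

The group on this aromatic carbon does matter in this assay, which the first pair could not show, since its step lay within the scatter. Replacing (morpholin-4-yl)carbonyl with sulfamoyl gives a step beyond the scatter (a 5.5-fold lower number from compound 2 to compound 3 (0.74 log units; beyond the scatter)), and sulfamoyl in place of hydrogen also clears the scatter (a 2.8-fold lower number from compound 1 to compound 3 (0.44 log units; beyond the scatter)), so a substituent here can lower the number rather than merely leave it unchanged, though this rests on the three compounds alone and compound 2 shows that not every large group does so. No separate measurement is available to explain why sulfamoyl differs from the other two groups on this carbon.

The compounds shown do not reveal which part of sulfamoyl goes with the lower number: a methylsulfonyl group, which has a methyl in place of the nitrogen, or a simple carboxamide would help to separate those parts. Also open, going by these compounds, is how a carboxylic acid or an amine would compare on this carbon, and whether sulfamoyl would give a similar step on another carbon of the same ring.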